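The compounds below may be only part of what the source reports. "The series", "measured", "known", "first", "only" and "open" are said of these compounds alone.

Working notes on the series. Compound 1 `Cc1nc(C)c(CN2CCN(c3cccc4[nH]c(-c5ccc(C(C)(C)C)cc5)nc34)CC2)o1` gives 31 nM in an assay on isolated protein for displacement of a labelled ligand from Gonadotropin-releasing hormone receptor (Homo sapiens); a lower number here means a stronger inhibitor, a higher number a weaker inhibitor. Compound 2 `CCc1nc(C)c(CN2CCN(c3cccc4[nH]c(-c5ccc(C(C)(C)C)cc5)nc34)CC2)o1` gives 37 nM, and compound 3 `CCCn1cnc(CN2CCN(c3cccc4[nH]c(-c5ccc(C(C)(C)C)cc5)nc34)CC2)c1C` gives 12 nM, the lowest number of the three measured; the two steps leading to it are a 2.6-fold lower number from compound 1 to compound 3 (0.41 log units; beyond the scatter) and a 3.1-fold lower number from compound 2 to compound 3 (0.49 log units; beyond the scatter). Compound 4 `CCCn1c(CC)nc(C)c1CN1CCN(c2cccc3[nH]c(-c4ccc(C(C)(C)C)cc4)nc23)CC1` is yet to be measured. It differs from compound 3 by 2-ethyl-4-methyl-1-propyl-1H-imidazol-5-yl in place of 5-methyl-1-propyl-1H-imidazol-4-yl on a saturated chain carbon bound to an amine nitrogen in a ring. The measured step that bears most directly on this change is a 1.2-fold higher number from compound 1 to compound 2 (0.08 log units; within the scatter), which is a methyl in place of hydrogen on a saturated chain carbon bound to an aromatic carbon within a related five-membered ring, and it stayed within the scatter. For the measured compounds named here, the present change also moves the point of attachment on the imidazole, for which no measured step exists, so the expectation rests on the one step available. In this assay compound 4 is therefore expected to change little, with an expected step of a 1.3-fold higher number from compound 3 to compound 4 (0.10 log units; within the scatter). The estimate for compound 4 is 15 nM, with a range from 6 nM to 40 nM.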

Compound 4, half-maximal inhibitory concentration: 57 nM
Beside the measured number, compound 4's estimate is 3.8-fold (0.58 log units) below it, outside the stated range (above it).
By their numbers in this assay, from the lowest: compound 3; then compounds 1, 2 and 4 (each within the scatter of the next).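

In this assay, replacing 5-methyl-1-propyl-1H-imidazol-4-yl with 2-ethyl-4-methyl-1-propyl-1H-imidazol-5-yl is not a neutral change: a 4.8-fold higher number from compound 3 to compound 4 (0.68 log units; beyond the scatter) shows that the small step seen between the two oxazoles does not carry over to this imidazole change. The lower number of compound 3 is also not shared by both imidazoles at this place, since a 1.5-fold higher number from compound 2 to compound 4 (0.19 log units; within the scatter) and a 1.8-fold higher number from compound 1 to compound 4 (0.26 log units; within the scatter) leave compound 4 level with both oxazoles. Among these four compounds, only compound 3 stands apart, so the ring type alone does not set the number.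

The compounds shown do not separate the added 2-ethyl group from the moved attachment point, nor show how a butyl chain in place of the propyl chain would read. No evidence on hand accounts for the step from compound 3 to compound 4.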